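This account rests on a few compounds, and the source may have more. Where it says the series, first, only, none or still open, it means among the compounds named here.

Measured compounds in a physicochemical assay for solubility, read by HPLC, with a stated time of 30 min; a higher number here means a more soluble compound, a lower number a less soluble compound:
- compound 1, `O=C(Nc1nc(-c2cccc(F)c2)cs1)c1ccc([N+](=O)[O-])o1`: 14.8 ug/mL
- compound 2, `O=C(Nc1nc(-c2cccc(OC3CCCC3)c2)cs1)c1ccc([N+](=O)[O-])o1`: 0.027 ug/mL
- compound 3, `O=C(Nc1nc(-c2cccc(NC(=O)C3CCCCC3)c2)cs1)c1ccc([N+](=O)[O-])o1`: 3.46 ug/mL

Compound 3 sits second highest of the three numbers. Its nearest neighbour is compound 1, a 4.3-fold lower number from compound 1 to compound 3 (0.63 log units; beyond the scatter); its furthest is compound 2, a 130-fold higher number from compound 2 to compound 3 (2.11 log units; beyond the scatter). The remaining step, a 550-fold lower number from compound 1 to compound 2 (2.74 log units; beyond the scatter), is the widest swing in the set.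

Compound 4, `O=C(Nc1nc(-c2cccc(NS(=O)(=O)Cc3ccccc3)c2)cs1)c1ccc([N+](=O)[O-])o1`, keeps the anilide nitrogen of compound 3 and changes only the group on it: benzylsulfonyl in place of cyclohexylcarbonyl on a nitrogen on an aromatic ring. Within the data shown here, no measured step exchanges one substituent on that nitrogen for another, so none bears directly on it. The two steps that touch the nitrogen-bearing position both run through compound 3: the modest drop from compound 1 and the large rise from compound 2. They show that this position moves the readout strongly when the whole substituent changes, but give no direction for a swap of the acyl group alone.

The step from compound 3 to compound 4 in this assay is therefore expected to be small, a 1.7-fold lower number from compound 3 to compound 4 (0.24 log units; within the scatter), in either direction and possibly within the scatter. Compound 4 is estimated at 2 ug/mL, with a range of 0.3 ug/mL to 10 ug/mL.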

Compound 4, solubility: 0.48 ug/mL
Estimate against measurement, compound 4: 4.2-fold (0.62 log units) above, within the range that was stated.
By their numbers in this assay, from the lowest: compound 2; then compound 4; then compound 3; then compound 1.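

Swapping only the group on the nitrogen is enough to shift the number in this assay: with benzylsulfonyl in place of cyclohexylcarbonyl on a nitrogen on an aromatic ring, there is a 7.2-fold lower number from compound 3 to compound 4 (0.86 log units; beyond the scatter) and the step lies beyond the scatter, so the group carried by that nitrogen counts, not the nitrogen alone. The (benzylsulfonyl)amino group stays clear of both earlier groups on the aromatic carbon, with an 18-fold higher number from compound 2 to compound 4 (1.25 log units; beyond the scatter) and a 31-fold lower number from compound 1 to compound 4 (1.49 log units; beyond the scatter) as its steps, which places both nitrogen-linked groups between fluoro and cyclopentyloxy in this series, with fluoro highest and cyclopentyloxy lowest. Nothing available accounts for the size or direction of the step from compound 3 to compound 4.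

That step changes the carbonyl to a sulfonyl and the cyclohexyl ring to a benzyl group together, so the compounds shown do not separate the two changes. A benzoyl or a cyclohexylmethylsulfonyl group on the same nitrogen would pull them apart, and a piperidine or a carboxylic acid on the outer ring remains an open question for this position.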